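This account rests on a few compounds, and the source may have more. Where it says the series, first, only, none or still open, it means among the compounds named here.

Compound 1 `N#CCC1=NN=C(c2ccc(Br)cc2)C(CC(=O)c2ccc(Br)cc2)O1` gives 16900 nM in a functional assay on SF-268 cells (Homo sapiens) for inhibition, read by sulforhodamine B assay, with a stated time of 48 h; on this read-out higher numbers stand for weaker inhibition of growth and lower numbers for stronger inhibition of growth.
Compound 2 `N#CCC1=NN=C(c2ccc([N+](=O)[O-])cc2)C(CC(=O)c2ccc(Br)cc2)O1` gives 16500 nM in this assay.
Compound 3 `N#CCC1=NN=C(c2ccc(Br)cc2)CO1` gives 10300 nM in this assay.

In this assay compound 2 stands second highest of the three numbers; its nearest neighbour is compound 1, and compound 3 is the furthest, yet both gaps lie within the scatter, so the three values cannot be ordered. Compound 4 `N#CCC1=NN=C(c2ccc([N+](=O)[O-])cc2)C(CC(=O)c2ccc([N+](=O)[O-])cc2)O1` differs from compound 2 by nitro in place of bromo on an aromatic carbon. Among the compounds with values here, one measured step bears on this change: a 1.0-fold lower number from compound 1 to compound 2 (0.01 log units; within the scatter), the same swap on the other aromatic ring. Accordingly the expected step of no change at the digits printed from compound 2 to compound 4 (within the scatter) is none beyond the scatter. Compound 4 is therefore estimated at 16500 nM, with a range from 8000 nM to 34000 nM.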

Compound 4, concentration for 50% growth inhibition: 2000 nM
The estimate for compound 4 lay 8.3-fold (0.92 log units) above the measured number; measured number outside the range, below it.
By their numbers in this assay, from the lowest: compound 4; then compounds 3, 2 and 1 (each within the scatter of the next).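

In this assay, nitro in place of bromo on this ring gives an 8.3-fold lower number from compound 2 to compound 4 (0.92 log units; beyond the scatter), while the same swap on the other aromatic ring gave a 1.0-fold lower number from compound 1 to compound 2 (0.01 log units; within the scatter), which lies within the scatter. The two rings therefore do not respond alike to this change, and only compound 4 separates from the rest of the set. Nothing at hand accounts for this step.

Within the data shown here, the step was seen only with nitro already on the other ring, so it remains open whether it would hold with bromo there. Also open, on these data alone, is how an amine or a carboxylic acid would fare in place of the nitro at this position.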